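The source may hold more compounds than are shown below. What is called first, only, known or untested is meant among the compounds shown, and "the series" means these compounds.

In a functional assay on SK-MEL-5 cells (Homo sapiens) for inhibition, read by sulforhodamine B assay, with a stated time of 48 h (on this read-out higher numbers stand for weaker inhibition of growth and lower numbers for stronger inhibition of growth), compound 1 `O=C(/C(=C\c1c(-c2ccccc2)[nH]c2ccccc12)S(=O)(=O)c1ccccc1)c1ccccc1` gives 9000 nM, the highest of the three numbers shown. Compound 3 `COc1ccc2[nH]c(-c3ccccc3)c(C=C(C#N)C#N)c2c1` gives 2900 nM, and compound 2 `COc1ccc(-c2[nH]c3ccc(OC)cc3c2/C=C(\C#N)S(=O)(=O)c2ccccc2)cc1` gives 319 nM, so compound 1 stands at the weak end of this small set, with both gaps beyond the usual scatter. Compound 4 `N#C/C(=C\c1c(-c2ccccc2)[nH]c2ccccc12)S(=O)(=O)c1ccccc1` has not yet been measured. It differs from compound 1 in one place: cyano in place of benzoyl on a double-bonded chain carbon bound to a double-bonded chain carbon and a sulfonyl sulfur. For the measured compounds named here, no measured pair shows this exact change, so the size of the step cannot be read from the data. Compound 2 also carries cyano on the double-bonded chain carbon bound to a sulfonyl sulfur, and in this assay compound 2 gives 319 nM. On that basis a lower number is expected for compound 4, with an expected step of a 6.0-fold lower number from compound 1 to compound 4 (0.78 log units; beyond the scatter). Compound 4 is estimated at 1500 nM, within a range from 400 nM to 5000 nM.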

Compound 4, concentration for 50% growth inhibition: 1820 nM
Compound 4: middle estimate off by 1.2-fold (0.08 log units), on the low side; the measured number falls inside the stated range.
By their numbers in this assay, from the lowest: compound 2; then compounds 4 and 3 (each within the scatter of the next); then compound 1.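

For the compounds shown here, replacing benzoyl with cyano at this chain carbon gives a 4.9-fold lower number from compound 1 to compound 4 (0.69 log units; beyond the scatter) in this assay, the first direct reading of a change at this position. In this one pair, the six-membered aromatic ring of benzoyl is not needed for growth inhibition, and the much smaller cyano group gives the stronger result. No available evidence explains this step. On these data alone, whether a carboxylic acid, an amide or a methyl ester at this carbon would give a lower or higher number remains open. So does whether the same step would appear on the core of compound 2.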